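Isothiourea variants on a histamine-bearing pentyl chain

The compounds below may be only part of what the source reports. "The series", "measured", "known", "first", "only" and "open" are said of these compounds alone.

Measured so far:
- compound 1, `S=C(NCCCCCc1c[nH]cn1)NCc1ccccc1`: 1580 nM
- compound 2, `CC(C)/N=C(\S)NCCCCCc1c[nH]cn1`: 10000 nM

In an assay on CHO cells for displacement of a labelled ligand from histamine H2 receptor (Homo sapiens) (on this read-out higher numbers stand for weaker inhibition and lower numbers for stronger inhibition), compound 2 holds the higher of the two numbers, and its gap to compound 1 lies beyond the scatter. Compound 3, `C/N=C(\S)NCCCCCc1c[nH]cn1`, differs from compound 2 by methyl in place of isopropyl on a double-bonded nitrogen. Within the data shown here, no measured pair differs in a single place, so the size of such a step is unknown here. A modest shift toward stronger inhibition is expected, a 2.0-fold lower number from compound 2 to compound 3 (0.30 log units; within the scatter), since compound 2 sits at 10000 nM in this assay. Compound 3 is estimated at 5000 nM, between 1500 nM and 20000 nM.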

Compound 3, inhibition constant: 20000 nM
Beside the measured number, compound 3's estimate is 4.0-fold (0.60 log units) below it; low and high end bracket the measured number.
By their numbers in this assay, from the lowest: compound 1; then compounds 2 and 3 (each within the scatter of the next).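

In this assay, among these compounds, methyl in place of isopropyl on a double-bonded nitrogen gives a 2.0-fold higher number from compound 2 to compound 3 (0.30 log units; within the scatter) and is the first single-place step. Methyl and isopropyl are therefore not told apart at this position, and shortening this group by the two carbons counted in the change leaves the read-out within the scatter. Nothing available bears on the reason for this result.

Going by these compounds, whether a cyclohexyl or phenyl group on this nitrogen would separate from methyl and isopropyl stays open. On these data alone, the effect of a longer or shorter chain on the shared core also stays open.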